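A few compounds are considered here, and "the series" means these few. Any claim that something is new, unique, unknown or untested is made for them only; others in the source may bear on it.

Compound 2 `O=c1c2ccccc2c(-c2cccnc2)nn1Cc1cccc(Cl)c1` is one of two compounds tested in an assay on isolated protein (Oryctolagus cuniculus) with Thromboxane-A synthase (Homo sapiens) as the target, tested at 1 uM (a lower number here means less inhibition, a higher number more inhibition at the concentration tested (going by the name of the read-out)), and in this assay compound 2 gives 95%. The other, compound 1 `CC(C)=CCn1nc(-c2cccnc2)c2ccccc2c1=O`, gives in this assay 94%; the step between them, a number 1 percentage points higher from compound 1 to compound 2 (within the scatter), lies within the scatter, so the two stand together rather than apart. Compound 3 `CC(=O)Cn1nc(-c2cccnc2)c2ccccc2c1=O` has not yet been measured. It differs from compound 2 in one place: acetyl in place of 3-chlorophenyl on a saturated chain carbon bound to an aromatic nitrogen. Among the measured compounds shown here, the only measured step that bears on this change is the one at the same position, a number 1 percentage points higher from compound 1 to compound 2 (within the scatter), in which a 3-chlorophenyl took the place of a 2-methylprop-1-en-1-yl without moving the number beyond the scatter. That single step shows the position accepts two different groups; it shows nothing about an acetyl, which resembles neither of them. The expected step for compound 3 is therefore a modest decline, a number 15 percentage points lower from compound 2 to compound 3 (beyond the scatter), carried with wide uncertainty. Compound 3 is estimated to give 80% in this assay, within a range from 50% to 97%.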

Compound 3, a percentage reported as inhibition, at one concentration (the size of the read-out at that concentration, not a potency): 13%
The estimate for compound 3 lay 67 percentage points above the measured number; the whole stated range lies above it.
By their numbers in this assay, from the lowest: compound 3; then compounds 1 and 2 (each within the scatter of the next).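

The position on a saturated chain carbon bound to an aromatic nitrogen proved far less forgiving than the first two compounds suggested: in this assay there is a number 82 percentage points lower from compound 2 to compound 3 (beyond the scatter) when acetyl replaces 3-chlorophenyl, and a number 81 percentage points lower from compound 1 to compound 3 (beyond the scatter) when acetyl replaces 2-methylprop-1-en-1-yl. Both steps are large, so two quite different groups keep the number high while acetyl does not, and the aromatic ring of 3-chlorophenyl cannot be the sole requirement, as 2-methylprop-1-en-1-yl has no ring. Acetyl is also smaller than 3-chlorophenyl and brings a hydrogen-bond acceptor that 3-chlorophenyl lacks, but nothing available explains the drop.

As far as these compounds go, what remains open is whether the low number goes with the carbonyl or with the short 2-oxopropyl chain as a whole, a question that a plain propyl chain, or a longer chain carrying the same carbonyl, would help to settle. It is also unknown how an amine or a carboxylic acid at this place would compare with the three groups shown.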